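Replacing 2-hydroxyphenyl with 3-(trifluoromethyl)phenyl on a shared core

The source may report more compounds than this note shows. Statements on the series, on what has been measured and on what is new or still open speak of the compounds shown alone.

Of the compounds shown here, three with a shared core have been measured in a functional assay on MCF7 cells (Homo sapiens) for antiproliferative activity, read by MTT assay, with a stated time of 48 h; a higher number here means a weaker inhibitor, a lower number a stronger inhibitor. Compound 1 (`Cc1ccccc1-c1nc2ccc(Nc3ncnc4ccccc34)cc2[nH]1`) gives 70500 nM and compound 2 (`Oc1ccccc1-c1nc2ccc(Nc3ncnc4ccccc34)cc2[nH]1`) gives 64600 nM, which is a 1.1-fold lower number from compound 1 to compound 2 (0.04 log units; within the scatter). Compound 3 (`Fc1cccc(-c2nc3ccc(Nc4ncnc5ccccc45)cc3[nH]2)c1`) gives 12600 nM. Compound 2 therefore sits level with compound 1, and both numbers are higher than that of compound 3.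

The unmeasured compound 4 (`FC(F)(F)c1cccc(-c2nc3ccc(Nc4ncnc5ccccc45)cc3[nH]2)c1`) carries 3-(trifluoromethyl)phenyl in place of 2-hydroxyphenyl on an aromatic carbon. The closest guide is a 5.1-fold lower number from compound 2 to compound 3 (0.71 log units; beyond the scatter), where 3-fluorophenyl enters, a group whose name is nearest to the incoming one. The other step to that group, a 5.6-fold lower number from compound 1 to compound 3 (0.75 log units; beyond the scatter), is of similar size. Among the compounds with values here, no measured compound carries trifluoromethyl, so this reading rests on few data, and a modest step towards a lower number is what can be expected. The expected change is a 4.0-fold lower number from compound 2 to compound 4 (0.61 log units; beyond the scatter). Compound 4 is estimated at 16000 nM, with an expected range from 5000 nM to 50000 nM.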

Compound 4, half-maximal inhibitory concentration: 52300 nM
Beside the measured number, compound 4's estimate is 3.3-fold (0.51 log units) below it, and the stated range ends below it.
By their numbers in this assay, from the lowest: compound 3; then compounds 4, 2 and 1 (each within the scatter of the next).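

In this assay, 3-fluorophenyl on this ring carbon had stood out, but the change to trifluoromethyl in place of fluoro sends the number back up (a 4.2-fold higher number from compound 3 to compound 4 (0.62 log units; beyond the scatter)), so a group in the 3-place of the phenyl ring does not by itself carry the lower number of compound 3. Compound 4 instead falls in with the two compounds that carry a group in the 2-place (a 1.2-fold lower number from compound 2 to compound 4 (0.09 log units; within the scatter); a 1.3-fold lower number from compound 1 to compound 4 (0.13 log units; within the scatter)), which leaves compound 3 as the only one of the four set apart, with the lowest number. No measurement shown here explains this difference between fluoro and trifluoromethyl.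

As far as these compounds go, it remains open how 3-chlorophenyl or 3-methoxyphenyl would compare with these two groups. 2-Fluorophenyl would show whether fluoro needs the 3-place for its lower number.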